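Compound 4: methanesulfonamido in place of a larger amine

The source may report more compounds than this note shows. Statements on the series, on what has been measured and on what is new or still open speak of the compounds shown alone.

In a functional assay on the whole organism for inhibition, with Mus musculus as the target (on this read-out higher numbers stand for an effect only at larger amounts of compound and lower numbers for an effect already at smaller amounts), compound 1 `CCN1CCCC1CNC(=O)c1cc(N(C)S(=O)(=O)N(C)C)ccc1OC` gives 36.2 mg/kg. Compound 2 `CCN1CCCC1CNC(=O)c1cc(N(C)S(=O)(=O)N(C)C)c(C)cc1OC` reaches only a limit of this assay, > 50 mg/kg. Compound 3 `CCN1CCCC1CNC(=O)c1cc(N(C)S(=O)(=O)N(C)C)c(Cl)cc1OC` gives 31.8 mg/kg in this assay, and against compound 1 the step is a 1.1-fold lower number from compound 1 to compound 3 (0.06 log units; within the scatter). Compound 4 `CCN1CCCC1CNC(=O)c1cc(NS(C)(=O)=O)c(Cl)cc1OC` differs from compound 3 by methanesulfonamido in place of (dimethylsulfamoyl)(methyl)amino on an aromatic carbon. Within the data shown here, the measured steps of an at least 1.3-fold higher number from compound 1 to compound 2 (0.14 log units; that floor lies within the scatter), a 1.1-fold lower number from compound 1 to compound 3 (0.06 log units; within the scatter) and an at least 1.5-fold lower number from compound 2 to compound 3 (0.19 log units; that floor lies within the scatter) all alter the group on the aromatic carbon, and none touches the sulfonamide, so no measured step bears directly on this change. An estimate can only lean on the narrow spread among the measured compounds: a step of a 1.1-fold higher number from compound 3 to compound 4 (0.04 log units; within the scatter) in this assay is expected, within the scatter. Compound 4 is therefore estimated at 35 mg/kg, between 12 mg/kg and 100 mg/kg.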

Compound 4, dose for half-maximal effect: 9.1 mg/kg
Compound 4: middle estimate off by 3.8-fold (0.59 log units), on the high side; the measured number lies below the stated range.
By their numbers in this assay, from the lowest: compound 4; then compounds 3 and 1 (each within the scatter of the next). At a limit, above all of these: compound 2.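

With the chloro group held fixed, this is the only change here that touches the sulfonamide, and methanesulfonamido in place of (dimethylsulfamoyl)(methyl)amino gives a 3.5-fold lower number from compound 3 to compound 4 (0.54 log units; beyond the scatter) in this assay as the only step among these compounds printed as beyond the scatter. The entering group is smaller and carries a hydrogen-bond donor that the leaving group lacks. Nothing measured here accounts for the step. The compounds shown leave open whether size or the donor matters, which the N-methyl methanesulfonamido group would separate, and whether a plain amine would serve at this position. They also leave open whether the step holds without the chloro group.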